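From chloro to methoxy: compound 2 to compound 3

This account rests on a few compounds, and the source may have more. Where it says the series, first, only, none or still open, it means among the compounds named here.

In an ADME assay on BHK-21 cells (Mesocricetus auratus) for cytotoxicity, read by MTT assay (a lower number here means that less compound is tolerated, a higher number that more compound is tolerated), compound 1 `COc1ccc(-c2nc3cc(/C(C)=N/NC(N)=O)ccc3[nH]2)cc1` stands as "not determined" (no result reported). Compound 2 `C/C(=N\NC(N)=S)c1ccc2[nH]c(-c3ccc(Cl)cc3)nc2c1` gives > 100000 nM, which is a limit of the assay and not a number. Compound 3 `COc1ccc(-c2nc3cc(/C(C)=N/NC(N)=S)ccc3[nH]2)cc1` carries methoxy in place of chloro on an aromatic carbon, para to a large group: methoxy in place of chloro on an aromatic carbon. Going by the values given here, no measured step gives a size for this change in this assay. The expected step that the limit leaves unreadable from compound 2 to compound 3 is therefore none beyond the scatter, with no direction expected. For compound 3 the estimated value is 120000 nM, with an expected range of 50000 nM to 300000 nM.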

Compound 3, half-maximal cytotoxic concentration: 13000 nM
For compound 3 the middle estimate is 9.2-fold (0.97 log units) above the measured one, and the stated range ends above it.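

In this assay, methoxy in place of chloro on the aromatic carbon gives an at least 7.6-fold lower number from compound 2 to compound 3 (0.88 log units; beyond the scatter), the first sign in the series that this position affects how much compound is tolerated. Compound 2 gives > 100000 nM, which is a limit of the assay and not a number. The true size of the step therefore stays unknown because one end of it is a limit: the limit of > 100000 nM in this assay, at which 1 of the 3 values shown sits.

From the compounds shown here alone, whether an amine or a hydroxyl group at this same place would give a number near compound 3 or a limit like compound 2 remains open.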